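A small change at the carbonyl of compound 1

The source may report more compounds than this note shows. Statements on the series, on what has been measured and on what is new or still open speak of the compounds shown alone.

Compound 1 `C/C=C/C(=O)N1CCCC(n2nc(-c3ccc(Oc4ccccc4)cc3)cc2C(=O)OCC)C1` gives 5100 nM
Compound 2 `C/C=C/C(=O)Nc1ccc(Cn2nc(-c3ccc(Oc4ccccc4)cc3)cc2CO)cc1` gives 12200 nM
Compound 3 `O=C(CCl)Nc1ccc(Cn2nc(-c3ccc(Oc4ccccc4)cc3)cc2C(=O)O)cc1` gives 4000 nM

These three values come from a functional assay on Rec1 cells (Homo sapiens) for inhibition, read by luminescence and CellTiter-Glo, with a stated time of 72 h (on this read-out lower numbers stand for stronger inhibition and higher numbers for weaker inhibition), and show modest inhibition overall. Compound 1 and compound 3 lie within the usual scatter of each other. Compound 2 stands beyond the scatter from compound 1 on the higher, weaker side.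

Compound 4 `C=CC(=O)N1CCCC(n2nc(-c3ccc(Oc4ccccc4)cc3)cc2C(=O)OCC)C1` keeps the core of compound 1 and differs in one place. It carries vinyl in place of prop-1-en-1-yl on a carbonyl carbon whose other neighbours are an amide-type nitrogen in a ring vinyl in place of prop-1-en-1-yl on a carbonyl carbon and nothing else in the structure changes.

Among the compounds with values here, no measured pair of compounds shows this change, so its size is a judgement and remains uncertain. A small move toward a lower number is expected in this assay and it would probably stay within the scatter. The estimated step is a 1.7-fold lower number from compound 1 to compound 4 (0.23 log units; within the scatter) and it could still turn out larger or point the other way. Compound 4 is estimated at 3000 nM with 900 nM to 9000 nM as the expected range.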

Compound 4, half-maximal inhibitory concentration: 13800 nM
Compound 4: middle estimate off by 4.6-fold (0.66 log units), on the low side; the whole stated range lies below it.
By their numbers in this assay, from the lowest: compounds 3 and 1 (each within the scatter of the next); then compounds 2 and 4 (each within the scatter of the next).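

Within the data shown here, this is the first comparison between compounds that differ in one place, and it shows that the group on this carbonyl carbon matters. In this assay, vinyl in place of prop-1-en-1-yl gives a 2.7-fold higher number from compound 1 to compound 4 (0.43 log units; beyond the scatter), a modest step toward weaker inhibition, so with the core of compound 1 held fixed, the prop-1-en-1-yl group is the better of these two. No supporting data bear on why the step goes this way.

The compounds shown leave open how a longer chain, or a chain carrying an amine, would compare in place of prop-1-en-1-yl on this carbonyl carbon. They also leave open whether the same change would shift compound 2 in the same direction.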